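Fluorine on the Carbonyl-Side Ring: Plasma Stability of Compound 4

A few compounds are considered here, and "the series" means these few. Any claim that something is new, unique, unknown or untested is made for them only; others in the source may bear on it.

In an ADME assay on a cell-free system (plasma, Homo sapiens) for metabolic stability, read by LC-MS (on this read-out higher numbers stand for a longer-lived compound and lower numbers for a shorter-lived compound), three compounds sharing one core have been measured. Compound 1 `CCCOC(=O)c1ccc(NC(=O)c2cccc(-c3cc(C(=O)Nc4ccncc4F)ccc3CN)c2)cc1` gives > 2 h, which is a limit of the assay rather than a number. Compound 2 `COC(=O)c1cccc(NC(=O)c2cccc(-c3cc(C(=O)Nc4ccncc4F)ccc3CN)c2)c1F` gives < 0.0834 h, also a limit. Compound 3 `COC(=O)c1ccc(C(=O)Nc2cccc(-c3cc(C(=O)Nc4ccncc4F)ccc3CN)c2)cc1` gives > 2 h, again a limit. Within the data shown here, compound 3 thus stands together with compound 1 at the long-lived end of what has been seen, and the one measured step is the large fall an at least 23-fold lower number from compound 1 to compound 2 (1.37 log units; beyond the scatter). Compound 4 `COC(=O)c1ccc(F)c(C(=O)Nc2cccc(-c3cc(C(=O)Nc4ccncc4F)ccc3CN)c2)c1` differs from compound 3 by 2-fluoro-5-(methoxycarbonyl)phenyl in place of 4-(methoxycarbonyl)phenyl on a carbonyl carbon. That measured step bears only loosely on this change: there too a fluorine entered the ring, but on an amide-type nitrogen and together with a change from propoxycarbonyl to methoxycarbonyl, whereas here the ring sits on a carbonyl carbon and the methoxycarbonyl stays. One therefore expects a downward step, smaller than that one, of an at least 2.0-fold lower number from compound 3 to compound 4 (0.30 log units; that floor lies within the scatter) in this assay. Compound 4 is estimated at 1 h, expected to fall between 0.2 h and 4 h.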

Compound 4, half-life: 0.883 h
For compound 4 the middle estimate is 1.1-fold (0.05 log units) above the measured one, within the range that was stated.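

In this assay compound 4 gives 0.883 h, the only value among the compounds shown that is a number and not a limit of the assay. Placing 2-fluoro-5-(methoxycarbonyl)phenyl on a carbonyl carbon, in place of 4-(methoxycarbonyl)phenyl, gives an at least 2.2-fold lower number from compound 3 to compound 4 (0.35 log units; beyond the scatter), so this position responds to the change even though the methoxycarbonyl group stays. The true size of that step remains unknown, because compound 3 stands at a limit: the limit of > 2 h in this assay, at which 2 of the 4 values shown sit.

The compounds shown do not separate the contribution of the fluorine from that of the altered placement of the methoxycarbonyl group, since the two enter together. They also leave open how this ring would behave with a propoxycarbonyl group or a carboxylic acid in place of the methoxycarbonyl group.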